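The source may hold more compounds than are shown below. What is called first, only, known or untested is meant among the compounds shown, and "the series" means these compounds.

Compound 1 `Cn1nc(Cc2nnc(SCC(=O)Nc3ccc(Cl)cc3Cl)n2CCC=O)c2ccccc2c1=O`: 4200 nM
Compound 2 `Cn1c(Cc2nn(CCC3OCCO3)c(=O)c3ccccc23)nnc1SCC(=O)Nc1ccc(Cl)cc1Cl`: 30000 nM

Both compounds were tested in an assay on NK92 cells for inhibition of interleukin-15 (Homo sapiens), read by AlphaScreen, with stated times of 30 min and 1 h; on this read-out lower numbers stand for stronger inhibition and higher numbers for weaker inhibition. Compound 2 gives the higher of the two numbers, 30000 nM. Within the data shown here, its only point of comparison, compound 1, gives a clearly lower number at 4200 nM, and this gap lies beyond the usual scatter of the measurement. The two compounds differ from each other in more than one place. No single structural step can be read from that gap.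

Compound 3 `Cn1c(Cc2nn(CCCO)c(=O)c3ccccc23)nnc1SCC(=O)Nc1ccc(Cl)cc1Cl` has not yet been measured. It differs from compound 2 in one place only: hydroxymethyl in place of 1,3-dioxolan-2-yl on a saturated chain carbon, two bonds along the chain from an aromatic nitrogen. Nothing among the two measured compounds shows how a change of this kind plays out in this assay. Among the measured compounds shown here, with no comparable step available, the expectation for compound 3 is a number not far from that of compound 2, a step of a 1.5-fold lower number from compound 2 to compound 3 (0.18 log units; within the scatter) that may well stay within the scatter. Compound 3 is therefore estimated at about 20000 nM in this assay, with a likely range from 5000 nM to 60000 nM.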

Compound 3, half-maximal inhibitory concentration: 30000 nM
Compound 3: middle estimate off by 1.5-fold (0.18 log units), on the low side, within the range that was stated.
By their numbers in this assay, from the lowest: compound 1; then compounds 2 and 3 (each within the scatter of the next).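

In this assay, putting hydroxymethyl in place of 1,3-dioxolan-2-yl on a saturated chain carbon, two bonds along the chain from an aromatic nitrogen, gives no change at the digits printed from compound 2 to compound 3 (within the scatter). At this position, then, a ring with 2 hydrogen-bond acceptors and no donor and an open chain end with 1 donor and 1 acceptor read alike, although the count of heavy atoms in the group falls from 5 to 2, and compound 3 stays at a high number, 30000 nM, so this change brings no stronger inhibition. No measurement at hand offers a reason for this result.

The two compounds compared here leave open whether an amine, a carboxylic acid or a longer chain at this chain end would shift the number beyond the scatter. They also leave open whether the same exchange of 1,3-dioxolan-2-yl for hydroxymethyl would read the same way on a compound that starts from a lower number than compound 2.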